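The compounds below may be only part of what the source reports. "The series", "measured", "known", "first", "only" and "open" are said of these compounds alone.

Measured compounds:
- compound 1 `CCC[C@@H](OC(C)=O)C1=C(Br)C(=C(Br)Br)OC1=O`: 2.1 ug/mL
- compound 2 `CCC[C@@H](OC(C)=O)C1=C(Br)[C@@](OC)(C(Br)Br)OC1=O`: 3.6 ug/mL
- compound 3 `CCC[C@@H](O)C1=C(Br)C(=C(Br)Br)OC1=O`: 6.7 ug/mL

In a functional assay on LNCaP cells (Homo sapiens) for cytotoxicity (a higher number here means that more compound is needed for the effect, a lower number that less compound is needed), compound 3 gives the highest of the three numbers. Its nearest neighbour is compound 2, whose value lies within the scatter of it, while compound 1 sits furthest away. Within the data shown here, the one step that separates compound 1 from compound 3 is a 3.2-fold higher number from compound 1 to compound 3 (0.50 log units; beyond the scatter), the change being hydrogen in place of acetyl on an oxygen on a saturated carbon.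

Compound 4 `CCCCC1=C(Br)C(=C(Br)Br)OC1=O` is not yet measured. It differs from compound 3 as follows: hydrogen in place of hydroxy on a saturated chain carbon bound to a double-bonded ring carbon and a saturated chain carbon. Among the measured compounds shown here, no measured step follows this exact change; the only step that touches the same oxygen is the one from compound 1 to compound 3, which moved the number modestly upward when acetyl was replaced by hydrogen. Removing the hydroxy altogether is a different change, and the data give no direct guide to its direction. The step in this assay is therefore expected to be small, a 1.5-fold lower number from compound 3 to compound 4 (0.17 log units; within the scatter), with wide uncertainty. For compound 4 the estimated value is 4.5 ug/mL, within a range from 1.5 ug/mL to 14 ug/mL.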

Compound 4, concentration for half-maximal effect: 9.3 ug/mL
For compound 4 the middle estimate is 2.1-fold (0.32 log units) below the measured one; the range from low to high includes it.
By their numbers in this assay, from the lowest: compounds 1, 2, 3 and 4 (each within the scatter of the next, the first and the last beyond it).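

In this assay, the change from 1-hydroxybutyl to butyl stays within the scatter (a 1.4-fold higher number from compound 3 to compound 4 (0.14 log units; within the scatter)), so at this saturated chain carbon the hydroxy and hydrogen cannot be told apart. Hydrogen in place of acetoxy on the same carbon lies beyond the scatter (a 4.4-fold higher number from compound 1 to compound 4 (0.65 log units; beyond the scatter)), and so, among these compounds, only the acetoxy of compound 1 stands apart at this position, while compound 3 and compound 4 do not separate from each other. Nothing available explains this difference.

From the compounds shown here alone, whether other groups on this carbon, such as an amine, a methoxy or a longer ester like propionyloxy, would fall with the acetoxy or with hydrogen remains open. Also open, going by these compounds, is how a longer chain in place of butyl would read in this assay.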